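Bifuran amidines: removing the aryl methoxy group

The source may report more compounds than this note shows. Statements on the series, on what has been measured and on what is new or still open speak of the compounds shown alone.

Compound 1, `N=C(N)c1ccc(-c2ccc(-c3ccc(F)cc3)o2)o1`, gives 490 nM in a functional assay on K562 cells (Homo sapiens) for inhibition, read by sulforhodamine B assay, with a stated time of 48 h; on this read-out lower numbers stand for stronger inhibition of growth and higher numbers for weaker inhibition of growth.
Compound 2, `N=C(N)c1ccc(-c2ccc(-c3ccc(Cl)cc3)o2)o1`, gives 1370 nM in this assay.
Compound 3, `COc1ccc(-c2ccc(-c3ccc(C(=N)N)o3)o2)cc1`, gives 490 nM in this assay.

Compound 3 stands level with compound 1 at the digits printed, the two of them together the lowest of the three numbers, while compound 2 sits apart: a 2.8-fold lower number from compound 2 to compound 3 (0.45 log units; beyond the scatter).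

Compound 4, `N=C(N)c1ccc(-c2ccc(-c3ccccc3)o2)o1`, differs from compound 3 in a single place: hydrogen in place of methoxy on an aromatic carbon, on an aromatic carbon of a six-membered aromatic ring of carbon only, para to a large group. Within the data shown here, no measured step removes a group to leave hydrogen at this position; the steps that bear on it are the exchanges among the three groups there, no change at the digits printed from compound 1 to compound 3 (within the scatter) and a 2.8-fold higher number from compound 1 to compound 2 (0.45 log units; beyond the scatter). Two unlike groups giving the same number suggests a step for compound 4 that stays within the scatter, with a modest rise as the more likely deviation, so the expected step is a 1.3-fold higher number from compound 3 to compound 4 (0.12 log units; within the scatter). Compound 4 is therefore estimated at 650 nM, within a range from 250 nM to 1700 nM.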

Compound 4, concentration for 50% growth inhibition: 660 nM
Estimate against measurement, compound 4: 1.0-fold (0.01 log units) below; measured number inside the range.
By their numbers in this assay, from the lowest: compounds 1, 3 and 4 (each within the scatter of the next); then compound 2.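

With hydrogen at this position, the group can go entirely without a measurable cost in this assay: the exchange for methoxy gives a 1.3-fold higher number from compound 3 to compound 4 (0.13 log units; within the scatter), and the exchange for fluoro gives a 1.3-fold higher number from compound 1 to compound 4 (0.13 log units; within the scatter). Chloro alone now stands apart among the four compounds, since the exchange for it gives a 2.1-fold lower number from compound 2 to compound 4 (0.32 log units; beyond the scatter), so the shared core with a bare aromatic ring belongs with the fluoro and methoxy compounds, and neither of those groups is needed to reach their level. Nothing available here accounts for why chloro differs from the other three.

The compounds shown leave open whether the chloro result is an isolated case or would be shared by bromo or trifluoromethyl at this position. They also leave open how an amine, a hydroxyl group or a longer chain such as ethoxy would fare there.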